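Swapping hexyl for 4-methoxyphenyl: a half-life estimate

The source may hold more compounds than are shown below. What is called first, only, known or untested is meant among the compounds shown, and "the series" means these compounds.

- compound 1 (`CCOC(=O)NCCCC(C)Nc1cc(OC)cc2cccnc12`) gives 15.1 h
- compound 2 (`CCCCCCOC(=O)NCCCC(C)Nc1cc(OC)cc2cccnc12`) gives 10.4 h

In an ADME assay on liver (Rattus norvegicus) for activation, read by HPLC (a lower number here means that the compound disappears faster, a higher number that the compound lasts longer), compound 2 stands within the usual scatter of compound 1, so the two cannot be told apart. Compound 3 (`COc1ccc(OC(=O)NCCCC(C)Nc2cc(OC)cc3cccnc23)cc1`) has 4-methoxyphenyl in place of hexyl on an oxygen next to a carbonyl group. Among the compounds with values here, only one measured step bears on this, a 1.5-fold lower number from compound 1 to compound 2 (0.16 log units; within the scatter), and it lies within the scatter. Within the data shown here, that step only extends a chain, whereas compound 3 brings in an aromatic ring that no measured compound carries, so it is a weak guide. A small move towards a lower number is expected, roughly the size of the scatter, and held loosely. The estimated change is a 1.7-fold lower number from compound 2 to compound 3 (0.24 log units; within the scatter) in this assay, with much uncertainty. For compound 3 the half-life is expected at 6 h, with 1.5 h to 14 h as the estimated range.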

Compound 3, half-life: 10.3 h
The estimate for compound 3 lay 1.7-fold (0.23 log units) below the measured number, within the range that was stated.
By their numbers in this assay, from the lowest: compounds 3, 2 and 1 (each within the scatter of the next).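

In this assay, 4-methoxyphenyl on an oxygen next to a carbonyl group gives a 1.0-fold lower number from compound 2 to compound 3 (0.00 log units; within the scatter) when it takes the place of hexyl, and a 1.5-fold lower number from compound 1 to compound 3 (0.17 log units; within the scatter) when it takes the place of ethyl. The position therefore accepts a six-membered aromatic ring of carbon only, as well as the two open chains, and the three compounds cannot be told apart in this assay. No supporting measurement is available to explain this result.

The compounds shown leave open whether any group at this position can separate itself from the scatter. An amine or a carboxylic acid in place of hexyl, or a phenyl ring without its methoxy group, would test how far this lack of separation extends.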